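Aryl swap on the oxadiazole-bearing position of the shared core

This account rests on a few compounds, and the source may have more. Where it says the series, first, only, none or still open, it means among the compounds named here.

Compound 2 `Cc1ccccc1-c1nnc(CSc2nnc(/N=C/c3ccccc3O)s2)o1` stands highest of the two numbers measured in a functional assay on MCF7 cells (Homo sapiens) for inhibition, read by CCK-8 assay; a higher number here means a weaker inhibitor, a lower number a stronger inhibitor: compound 2 gives 9360 nM, and its nearest neighbour compound 1 `Oc1ccccc1/C=N/c1nnc(SCc2nnc(-c3ccc(Br)cc3)o2)s1` gives 8320 nM. Among the compounds with values here, the only step between the two, a 1.1-fold higher number from compound 1 to compound 2 (0.05 log units; within the scatter), is within the scatter and concerns the same aromatic carbon of the shared core that is altered now.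

Compound 3 `COc1ccc(-c2nnc(CSc3nnc(/N=C/c4ccccc4O)s3)o2)cc1` is not yet measured. Its change from compound 2 is 4-methoxyphenyl in place of 2-methylphenyl on an aromatic carbon. Within the data shown here, the one step that bears on this place, a 1.1-fold higher number from compound 1 to compound 2 (0.05 log units; within the scatter), shows that exchanging one aryl group for another there left this assay essentially unchanged; nothing else measured addresses this position. On that basis no step beyond the scatter is expected from compound 2 to compound 3, that is a 1.0-fold lower number from compound 2 to compound 3 (0.02 log units; within the scatter). Among the measured compounds shown here, compound 3 is therefore estimated at 9000 nM in this assay, with a range from 3000 nM to 27000 nM, the width reflecting that only one aryl exchange is available as a guide.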

Compound 3, half-maximal inhibitory concentration: 4560 nM
For compound 3 the middle estimate is 2.0-fold (0.30 log units) above the measured one; the measured number falls inside the stated range.
By their numbers in this assay, from the lowest: compounds 3, 1 and 2 (each within the scatter of the next, the first and the last beyond it).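

The aryl position is not fully silent in this assay: 4-methoxyphenyl in place of 2-methylphenyl gives a 2.1-fold lower number from compound 2 to compound 3 (0.31 log units; beyond the scatter), a modest step and the first beyond the scatter at this place. Methoxy in place of bromo gives a 1.8-fold lower number from compound 1 to compound 3 (0.26 log units; within the scatter), which stays within the scatter, so 4-bromophenyl and 4-methoxyphenyl cannot be told apart here. No supporting data are available to explain the step seen at this position.

The exchange of 2-methylphenyl for 4-methoxyphenyl alters both the substituent and its place on the phenyl ring, and the compounds shown do not separate these two changes. Also open, from the compounds shown here alone, is how an amine or a carboxylic acid on that phenyl ring would read in this assay.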